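Removing the Hydroxy Group From Compound 3

This account rests on a few compounds, and the source may have more. Where it says the series, first, only, none or still open, it means among the compounds named here.

Compound 1 `O=C(O)Cc1sc(C(c2ccc(F)cc2)c2ccc(F)cc2)nc1-c1ccnc(F)c1`, compound 2 `O=C(O)Cc1sc(C(c2ccc(F)cc2)c2ccc(F)cc2)nc1-c1ccco1` and compound 3 `O=C(O)Cc1sc(C(c2ccc(F)cc2)c2ccc(F)cc2)nc1-c1ccnc(O)c1` share one core and differ only in the aromatic ring attached to it. In an in vitro functional assay on HEK285-7 cells for antagonist activity at prostaglandin D2 receptor 2 (Homo sapiens), read by BRET and beta-arrestin recruitment (a higher number here means a larger maximal response, a lower number a smaller maximal response), compound 1 gives 80%, compound 2 gives 80% and compound 3 gives 60%, the lowest of the three. The step of a number 20 percentage points lower from compound 1 to compound 3 (beyond the scatter) and the step of a number 20 percentage points lower from compound 2 to compound 3 (beyond the scatter) both set compound 3 apart as the weakest, while the step of no change at the digits printed from compound 1 to compound 2 (within the scatter) shows the other two rings behaving alike. Compound 4 `O=C(O)Cc1sc(C(c2ccc(F)cc2)c2ccc(F)cc2)nc1-c1ccncc1` differs from compound 3 by hydrogen in place of hydroxy on an aromatic carbon. The step of a number 20 percentage points lower from compound 1 to compound 3 (beyond the scatter), which brought the hydroxy in, is the nearest guide. Undoing it is expected to raise the response, by a step of a number 18 percentage points higher from compound 3 to compound 4 (beyond the scatter). Compound 4 is thus expected to reach 78%, with a range from 65% to 90%.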

Compound 4, largest response reached (reported as efficacy), in percent of the reference or control that the assay uses: 80%
Compound 4: the middle estimate sits 2 percentage points below what was measured, within the range that was stated.
By their numbers in this assay, from the lowest: compound 3; then compounds 1, 2 and 4 (each within the scatter of the next).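

In this assay, taking the hydroxy away gives a number 20 percentage points higher from compound 3 to compound 4 (beyond the scatter), so the lower response of compound 3 goes with the hydroxy group and not with the ring that carries it. At this place on the ring, hydrogen and fluoro give no change at the digits printed from compound 1 to compound 4 (within the scatter), so the fluoro of compound 1 has no visible effect here. Exchanging the whole ring gives no change at the digits printed from compound 2 to compound 4 (within the scatter), which places pyridin-4-yl alongside furan-2-yl.

Going by these compounds, whether an amine or a methoxy group here would track the hydroxy or the fluoro stays open. Nothing available explains the drop seen with the hydroxy.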